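Aryl in place of alkyl at the saturated ring carbon

The compounds below may be only part of what the source reports. "The series", "measured", "known", "first", "only" and "open" are said of these compounds alone.

Measured compounds:
compound 1 `CCCC1C(=O)N(C)c2cnc(Nc3ccc(S(N)(=O)=O)cc3)nc2N1C` — 206 nM
compound 2 `CN1C(=O)C(CC2CC2)N(C)c2nc(Nc3ccc(S(N)(=O)=O)cc3)ncc21` — 211 nM
compound 3 `COc1cccc(C2C(=O)N(C)c3cnc(Nc4ccc(S(N)(=O)=O)cc4)nc3N2C)c1` — 954 nM

In an assay on Sf9 cells for inhibition of serine/threonine-protein kinase 4 (Homo sapiens), read by luminescence and ADP-Glo, with a stated time of 1 h, in the presence of a further agent that is not named here (a higher number here means a weaker inhibitor, a lower number a stronger inhibitor), compound 2 gives 211 nM, the second highest of the three numbers; its nearest neighbour is compound 1 with a 1.0-fold higher number from compound 1 to compound 2 (0.01 log units; within the scatter), its furthest compound 3 with a 4.5-fold higher number from compound 2 to compound 3 (0.66 log units; beyond the scatter). The unmeasured compound 4 `CCc1ccccc1C1C(=O)N(C)c2cnc(Nc3ccc(S(N)(=O)=O)cc3)nc2N1C` differs from compound 2 as follows: 2-ethylphenyl in place of cyclopropylmethyl on a saturated ring carbon.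

Among the measured compounds shown here, two measured steps bear on this change, both replacing a saturated chain on the same ring carbon with an aromatic ring: a 4.6-fold higher number from compound 1 to compound 3 (0.67 log units; beyond the scatter) and a 4.5-fold higher number from compound 2 to compound 3 (0.66 log units; beyond the scatter). Both are modest losses beyond the scatter. The 2-ethylphenyl of compound 4 is another six-membered aromatic ring of carbon only, so a step of the same kind is expected, that is a weaker inhibitor than compound 2, with little ground to tell whether it lands closer to or further from compound 3. Compound 4 is therefore estimated at 900 nM, with a range of 300 nM to 3000 nM, which means an expected step of a 4.3-fold higher number from compound 2 to compound 4 (0.63 log units; beyond the scatter).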

Compound 4, half-maximal inhibitory concentration: 51 nM
Compound 4: middle estimate off by 18-fold (1.25 log units), on the high side; measured number below the stated range.
By their numbers in this assay, from the lowest: compound 4; then compounds 1 and 2 (each within the scatter of the next); then compound 3.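

In this assay, an aromatic ring on this saturated ring carbon is not in itself a loss: 2-ethylphenyl gives a 4.1-fold lower number from compound 2 to compound 4 (0.62 log units; beyond the scatter) in place of cyclopropylmethyl and a 4.0-fold lower number from compound 1 to compound 4 (0.61 log units; beyond the scatter) in place of propyl, the opposite direction to the steps seen with 3-methoxyphenyl. The choice of aromatic group therefore matters more here than the change from chain to ring, with a 19-fold lower number from compound 3 to compound 4 (1.27 log units; beyond the scatter) between the two aromatic groups, the largest step in the set. Nothing measured here accounts for the lower number of 2-ethylphenyl.

Ethyl and methoxy cannot be separated from their places on the aromatic ring, as 2-ethylphenyl and 3-methoxyphenyl differ in both. From the compounds shown here alone, it also remains open how plain phenyl, or an amine in place of the ethyl, would compare.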